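The source may report more compounds than this note shows. Statements on the series, on what has been measured and on what is new or still open speak of the compounds shown alone.

Measured so far in a functional assay on MGC-803 cells (Homo sapiens) for cytotoxicity, read by MTT assay, with a stated time of 72 h; a lower number here means a stronger inhibitor, a higher number a weaker inhibitor:
- compound 1 `O=C1C(=Cc2ccc(Br)cc2)C(=O)N(c2ccc(Cl)cc2)N1c1ccc(Cl)cc1` at 16900 nM
- compound 2 `COc1cc(C=C2C(=O)N(c3ccc(Cl)cc3)N(c3ccc(Cl)cc3)C2=O)cc(OC)c1OC` at 17300 nM

Compound 1 at 16900 nM and compound 2 at 17300 nM lie within the scatter of each other, so compound 1 stands level with compound 2 and neither can be ranked. Next is compound 3 `O=C1C(=Cc2cccc(Cl)c2)C(=O)N(c2ccc(Cl)cc2)N1c1ccc(Cl)cc1`, which differs from compound 1 3-chlorophenyl in place of 4-bromophenyl on a double-bonded chain carbon bound to a double-bonded ring carbon and carries 3-chlorophenyl in place of 4-bromophenyl on a double-bonded chain carbon bound to a double-bonded ring carbon. Among the compounds with values here, no single-place step has been measured, so direct support is lacking. In this assay no step beyond the scatter is expected, in either direction. The step expected on this estimate is a 1.1-fold lower number from compound 1 to compound 3 (0.05 log units; within the scatter) and it remains uncertain. For compound 3 the estimated value is 15000 nM with an expected range from 6000 nM to 35000 nM in this assay.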

Compound 3, half-maximal inhibitory concentration: 14400 nM
Compound 3: middle estimate off by 1.0-fold (0.02 log units), on the high side, within the range that was stated.
By their numbers in this assay, from the lowest: compounds 3, 1 and 2 (each within the scatter of the next).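

Within the data shown here, the step of a 1.2-fold lower number from compound 1 to compound 3 (0.07 log units; within the scatter) in this assay is the first single-place comparison. On a double-bonded chain carbon bound to a double-bonded ring carbon, 3-chlorophenyl and 4-bromophenyl read level, so this position takes both groups with no difference that can be told from the scatter. No measurement accompanies this result that could explain it.

Since the halogen and its place on the phenyl ring differ together in this step, their separate contributions remain unresolved, and 4-chlorophenyl or 3-bromophenyl at this position would be needed to separate them. It also remains open whether this position stays as flat with a phenyl ring carrying an amine or a carboxylic acid, groups absent from the compounds shown.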